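The source may report more compounds than this note shows. Statements on the series, on what has been measured and on what is new or still open speak of the compounds shown alone.

Measured so far:
compound 1, `CC(=O)N1CCC(C(=O)N(CCCN2CCN(Cc3ccc(S(C)(=O)=O)cc3)CC2)c2ccc(C)c(Cl)c2)CC1` — > 49200 nM
compound 2, `CC(=O)N1CCC(C(=O)N(CCCN2CCN(Cc3ccc(Cl)cc3)CC2)c2ccc(C)c(Cl)c2)CC1` — 37600 nM

In an ADME assay (Homo sapiens) for cytotoxicity (on this read-out higher numbers stand for lower toxicity in this test and lower numbers for higher toxicity in this test), compound 1 gives > 49200 nM; this is a limit of the assay, not a number. In this assay, going by the values given here, compound 2 gives 37600 nM, the only number among the two results. The step of an at least 1.3-fold lower number from compound 1 to compound 2 (0.11 log units; that floor lies within the scatter) is only a floor, because the result for compound 1 is the limit of > 49200 nM in this assay, at which 1 of the 2 values shown sits, and that floor lies within the usual scatter.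

Compound 3, `CC(=O)N1CCC(C(=O)N(CCCN2CCN(Cc3ccccc3)CC2)c2ccc(C)c(Cl)c2)CC1`, differs from compound 2 by hydrogen in place of chloro on an aromatic carbon. Among the compounds with values here, the one measured step touches the same aromatic carbon, an at least 1.3-fold lower number from compound 1 to compound 2 (0.11 log units; that floor lies within the scatter), and it did not move beyond the scatter. On that basis the expected step of no change at the digits printed from compound 2 to compound 3 (within the scatter) is none beyond the scatter. Compound 3 is therefore expected to give about 37600 nM in this assay, with a range from 15000 nM to 90000 nM.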

Compound 3, half-maximal cytotoxic concentration: 101000 nM
For compound 3 the middle estimate is 2.7-fold (0.43 log units) below the measured one, outside the stated range (above it).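

In this assay, going by these compounds alone, hydrogen in place of chloro gives a 2.7-fold higher number from compound 2 to compound 3 (0.43 log units; beyond the scatter), the only step at this aromatic carbon printed as beyond the scatter. The position, para to a large group, therefore does register in this read-out: with the 4-chlorobenzyl group changed to plain benzyl, the higher number stands for lower toxicity in this test. Compound 1 gives > 49200 nM, which is a limit and not a number, so its step to compound 3 cannot be read: the limit of > 49200 nM in this assay, at which 1 of the 3 values shown sits.

Still open, on these data alone, is how a fluoro, a methoxy or a dimethylamino group on this same carbon would read in this assay. The compounds shown also leave open whether the same change from chloro to hydrogen would give a step of similar size on the other aromatic ring of the shared core.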